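Phenyl in place of propyl on a carbonyl carbon

The source may report more compounds than this note shows. Statements on the series, on what has been measured and on what is new or still open speak of the compounds shown alone.

In a functional assay on U-87MG ATCC cells (Homo sapiens) for inhibition (on this read-out lower numbers stand for stronger inhibition and higher numbers for weaker inhibition), compound 1 `COc1cc(/C=C/C(=O)c2cccc(NC(=O)c3ccco3)c2)ccc1O` gives 6.65 ug/mL, compound 2 `COc1cc(/C=C/C(=O)c2cccc(N)c2)ccc1O` gives 7.71 ug/mL, and compound 3 `CCCC(=O)Nc1cccc(C(=O)/C=C/c2ccc(O)c(OC)c2)c1` gives 5.56 ug/mL. Compound 3 lies within the scatter of both others, so the three numbers set it apart from neither.

Compound 4 `COc1cc(/C=C/C(=O)c2cccc(NC(=O)c3ccccc3)c2)ccc1O` is the next compound to consider. It differs from compound 3 by one exchange, phenyl in place of propyl on a carbonyl carbon. The same difference reads as (propylcarbonyl)amino to benzamido.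

Among the compounds with values here, no measured compound carries the benzoyl group, so the expectation rests on nearby changes. The closest is the exchange of furan-2-yl for propyl at that same carbonyl carbon, the step of a 1.2-fold lower number from compound 1 to compound 3 (0.08 log units; within the scatter), which stays within the scatter. Removing the whole acyl group also leaves the number within the scatter, both in the step of a 1.2-fold higher number from compound 1 to compound 2 (0.06 log units; within the scatter) and in the step of a 1.4-fold lower number from compound 2 to compound 3 (0.14 log units; within the scatter). With these three steps this small, no step beyond the scatter is anticipated in this assay, and neither direction is favoured. The expected step is a 1.1-fold higher number from compound 3 to compound 4 (0.03 log units; within the scatter), which would lie within the scatter. Compound 4 is estimated at 6 ug/mL, with an expected range of 3.5 ug/mL to 10.5 ug/mL.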

Compound 4, half-maximal inhibitory concentration: 8.82 ug/mL
Beside the measured number, compound 4's estimate is 1.5-fold (0.17 log units) below it, and the stated range covers the measured number.
By their numbers in this assay, from the lowest: compounds 3, 1, 2 and 4 (each within the scatter of the next).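

In this assay placing phenyl where propyl stood on this carbonyl carbon gives a 1.6-fold higher number from compound 3 to compound 4 (0.20 log units; within the scatter) and placing it where furan-2-yl stood gives a 1.3-fold higher number from compound 1 to compound 4 (0.12 log units; within the scatter) so a six-membered aromatic ring of carbon only cannot be told apart from either group on this read-out. Set against the free nitrogen, the benzoyl group gives a 1.1-fold higher number from compound 2 to compound 4 (0.06 log units; within the scatter) and thus joins the propylcarbonyl and (furan-2-yl)carbonyl groups in leaving the number within the scatter of compound 2. No measurement is available here that would account for how little these exchanges register.

The compounds shown leave open whether another kind of group on this carbonyl carbon, such as a longer alkyl chain, a carboxylic acid or a phenyl ring carrying an amine, would give a step beyond the scatter. They also leave open whether this read-out responds to changes anywhere else on the shared core, since all four compounds differ only in what sits on this one nitrogen.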